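The source may report more compounds than this note shows. Statements on the series, on what has been measured and on what is new or still open speak of the compounds shown alone.

Compound 1 `CC1(C)c2[nH]nc(NC(=O)c3ccccc3)c2CN1Cc1ccccc1F` gives 450 nM in an assay on Sf21 cells for inhibition of high affinity nerve growth factor receptor (Homo sapiens), read by HTRF, with a stated time of 30 min, in the presence of a further agent that is not named here; a lower number here means a stronger inhibitor, a higher number a weaker inhibitor. Compound 2 `CC1(C)c2[nH]nc(NC(=O)c3ccccc3)c2CN1Cc1cc(F)ccc1F` gives 480 nM in this assay, the higher of the two numbers shown, with compound 1 sitting within the scatter of it. For the measured compounds named here, the step of a 1.1-fold higher number from compound 1 to compound 2 (0.03 log units; within the scatter) is the only measured change on the group at the saturated chain carbon bound to the amine nitrogen in the ring. Compound 3 `Cc1ccc(CN2Cc3c(NC(=O)c4ccccc4)n[nH]c3C2(C)C)cc1F` carries 3-fluoro-4-methylphenyl in place of 2,5-difluorophenyl on a saturated chain carbon bound to an amine nitrogen in a ring. Going by the values given here, the change from 2,5-difluorophenyl to 3-fluoro-4-methylphenyl has no direct precedent here; the one related step stayed within the scatter, so no step beyond the scatter is expected in this assay. Compound 3 is therefore estimated at 450 nM, with a range of 180 nM to 1100 nM. The expected step from compound 2 is a 1.1-fold lower number from compound 2 to compound 3 (0.03 log units; within the scatter).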

Compound 3, half-maximal inhibitory concentration: 940 nM
The estimate for compound 3 lay 2.1-fold (0.32 log units) below the measured number, within the range that was stated.
By their numbers in this assay, from the lowest: compounds 1, 2 and 3 (each within the scatter of the next, the first and the last beyond it).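

At the group on a saturated chain carbon bound to an amine nitrogen in a ring, the series now has its first step beyond the scatter: a 2.1-fold higher number from compound 1 to compound 3 (0.32 log units; beyond the scatter) is modest, while a 2.0-fold higher number from compound 2 to compound 3 (0.29 log units; within the scatter) stays within the scatter. Replacing a ring with fluoro only by 3-fluoro-4-methylphenyl therefore moves the number only slightly in this assay. Nothing available accounts for this step.

From the compounds shown here alone, it remains open which part of the 3-fluoro-4-methylphenyl change carries the step. Also open, going by these compounds, is how an amine or a carboxylic acid on this ring would read.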